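Compound 3 and its chloro counterpart

The compounds below may be only part of what the source reports. "The series", "measured", "known", "first", "only" and "open" are said of these compounds alone.

Compound 1 `C[C@@H](Nc1c(C(=O)NCc2ccc(F)cc2)nc(Br)c2cccnc12)c1ccccc1`: > 20000 nM (a limit, not a number)
Compound 2 `N[C@H]1CC[C@H](Nc2c(C(=O)NCc3ccc(Oc4ccccc4)cc3)nc(Br)c3cccnc23)CC1`: "not determined" (no result reported)
Compound 3 `COc1ccc(CNC(=O)c2nc(Br)c3cccnc3c2N[C@H]2CC[C@H](N)CC2)cc1`: 3000 nM

These three compounds share one core and were tested for cytotoxicity in a functional assay on HCT-116 cells (Homo sapiens) for cytotoxicity, read by MTT assay, with a stated time of 72 h; on this read-out lower numbers stand for stronger inhibition and higher numbers for weaker inhibition. Among them, compound 3 gives 3000 nM, the only actual number in the set. Compound 1 reaches only a limit of this assay, recorded as > 20000 nM. Compound 2 has no usable result, and its entry reads "not determined" (no result reported). Compound 3 therefore stands alone as the one firm reference point.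

The next compound to be tested is compound 4 `N[C@H]1CC[C@H](Nc2c(C(=O)NCc3ccc(Cl)cc3)nc(Br)c3cccnc23)CC1`, which keeps everything in compound 3 except for one substituent. The change is chloro in place of methoxy on an aromatic carbon, turning the 4-methoxybenzyl group into a 4-chlorobenzyl group.

For the measured compounds named here, no two measured compounds differ in only one place, so this swap has no direct precedent in the data. With nothing to suggest a large shift in either direction, no change beyond the usual scatter is expected in this assay. The expected step is a 1.2-fold lower number from compound 3 to compound 4 (0.08 log units; within the scatter).

For compound 4 the estimated value is 2500 nM, with an expected range from 800 nM to 8000 nM.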

Compound 4, half-maximal inhibitory concentration: 4000 nM
The estimate for compound 4 lay 1.6-fold (0.20 log units) below the measured number; the measured number falls inside the stated range.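

In this assay, for the compounds shown here, chloro in place of methoxy on an aromatic carbon, para to a large group, gives a 1.3-fold higher number from compound 3 to compound 4 (0.12 log units; within the scatter), the first step in this set between two compounds that differ in one place. The 4-chlorobenzyl and 4-methoxybenzyl groups thus cannot be told apart in this assay, even though the swap removes a heavy atom and the hydrogen-bond acceptor of the methoxy group, so this position tolerates this particular change without a readable shift. Compound 1 alone is recorded as a limit of the assay and not a number, whereas this step rests on two actual numbers: the limit of > 20000 nM in this assay, at which 1 of the 4 values shown sits.

Since this one pair holds a single swap, it leaves open whether a group of another kind at the same place, such as an amine or a carboxylic acid, would move the number beyond the scatter. As far as these compounds go, the entry of compound 2, which carries a phenoxy group at this place, holds no result, so any step to or from it cannot be read, and how a far larger group behaves here stays unknown.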